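The compounds below may be only part of what the source reports. "The series", "measured", "known", "first", "only" and "open" are said of these compounds alone.

Series notes. The shared core carries a cyanoguanidine linked to a pyridine ring, with the substituent on the double-bonded nitrogen varied. Compound 1 `CCCC/N=C(\NC#N)Nc1cccnc1` bears butyl there; compound 2 `CCCCC/N=C(\NC#N)Nc1cccnc1` pentyl; compound 3 `CCC(C)/N=C(\NC#N)Nc1cccnc1` sec-butyl; compound 4 `CCC(CC)/N=C(\NC#N)Nc1cccnc1` pentan-3-yl and is not yet measured.

In a functional assay on the whole organism (blood, strain Wistar-Okamoto) with Rattus norvegicus as the target, with a stated time of 5 days (on this read-out higher numbers stand for an effect only at larger amounts of compound and lower numbers for an effect already at smaller amounts), compound 1 gives 20 mg/kg. In this assay compound 2 gives 20 mg/kg. In this assay compound 3 gives 20 mg/kg. The three measured compounds thus sit level with one another: no change at the digits printed from compound 1 to compound 2 (within the scatter), no change at the digits printed from compound 1 to compound 3 (within the scatter), no change at the digits printed from compound 2 to compound 3 (within the scatter).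

The change from compound 1 to compound 2 is methyl in place of hydrogen on a saturated chain carbon, four bonds along the chain from a double-bonded nitrogen, and its step was no change at the digits printed from compound 1 to compound 2 (within the scatter). The change from compound 3 to compound 4 is methyl in place of hydrogen on a saturated chain carbon, two bonds along the chain from a double-bonded nitrogen. It is the same kind of change, not the same: in compound 2 the methyl enters four bonds along the chain from the double-bonded nitrogen, in compound 4 two bonds along the chain from it. The two cores differ by sec-butyl in place of butyl on a double-bonded nitrogen.

Going from compound 3 to compound 4, a step of about the same size as the earlier one is expected, namely no change at the digits printed from compound 3 to compound 4 (within the scatter), because compound 1 to compound 2 gave no change at the digits printed from compound 1 to compound 2 (within the scatter) and because compound 1 to compound 3 gave no change at the digits printed from compound 1 to compound 3 (within the scatter), so that neither lengthening nor branching of the chain has moved the read-out so far. Compound 4 is therefore estimated at 20 mg/kg in this assay, with an expected range from 10 mg/kg to 40 mg/kg.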

Compound 4, minimum effective dose: 20 mg/kg
The estimate for compound 4 equals the measured number at the digits printed; the measured number falls inside the stated range.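

In this assay the methyl on a saturated chain carbon, two bonds along the chain from a double-bonded nitrogen, gives no change at the digits printed from compound 3 to compound 4 (within the scatter), and the wider comparisons read the same way: pentan-3-yl in place of pentyl gives no change at the digits printed from compound 2 to compound 4 (within the scatter), and pentan-3-yl in place of butyl gives no change at the digits printed from compound 1 to compound 4 (within the scatter). Set beside the earlier step, the methyl change carries from the core of compound 1 to the core of compound 3 with no gap beyond the scatter: the same change on two cores in this assay, no change at the digits printed (within the scatter) from compound 1 to compound 2 and no change at the digits printed (within the scatter) from compound 3 to compound 4, 1.0-fold (0.00 log units) apart, within the scatter of two such steps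

This agreement is only between two steps that did not move the read-out, with the methyl entering at different places along the chain, so it does not show that a change with a measurable effect would carry between cores in the same way, nor that the result extends to any core beyond these two.

The compounds shown leave open whether any group on the double-bonded nitrogen moves the minimum effective dose away from the level shared by this series. A much longer chain such as octyl, a more crowded tert-butyl group, or a chain ending in an amine or a carboxylic acid would test how far this flat stretch extends.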